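Solubility notes: aryl amide in place of acetamide on compound 3

The source may hold more compounds than are shown below. What is called first, only, known or untested is meant among the compounds shown, and "the series" means these compounds.

Compound 3 `CC(=O)NC1=NN(c2ccc(Cl)c(Cl)c2)CC1` is the less soluble of the two numbers in a physicochemical assay for solubility, measured as kinetic solubility, with a stated time of 1 h, at pH 7.4 (a lower number here means a less soluble compound, a higher number a more soluble compound), giving 31000 nM. Compound 2 `CS(=O)(=O)Nc1nc(-c2ccc(Cl)c(Cl)c2)cs1` gives 429000 nM in this assay, a gap beyond the scatter. Compound 1 `Cn1ncc([N+](=O)[O-])c1C(=O)Nc1nc(-c2ccc(Cl)c(Cl)c2)cs1` gives < 1000 nM, which is a limit of this assay and not a number. Compound 4 `O=C(NC1=NN(c2ccc(Cl)c(Cl)c2)CC1)c1ccncc1F` differs from compound 3 by 3-fluoropyridin-4-yl in place of methyl on a carbonyl carbon. No measured step matches this change, so the direction is judged from what is shown: compound 1, the other amide in the set, sits at the limit of < 1000 nM in this assay, at which 1 of the 3 values shown sits. A downward step is expected, a 6.2-fold lower number from compound 3 to compound 4 (0.79 log units; beyond the scatter), beyond the scatter. Compound 4 is therefore estimated at 5000 nM, within 1000 nM to 25000 nM, with a fair chance that only a limit is reported.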

Compound 4, solubility: 36000 nM
Compound 4: middle estimate off by 7.2-fold (0.86 log units), on the low side, outside the stated range (above it).
By their numbers in this assay, from the lowest: compounds 3 and 4 (each within the scatter of the next); then compound 2. At a limit, below all of these: compound 1.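

On a carbonyl carbon, 3-fluoropyridin-4-yl in place of methyl gives a 1.2-fold higher number from compound 3 to compound 4 (0.06 log units; within the scatter) in this assay, so this position takes the aromatic ring with no change beyond the scatter. Compound 1 stays alone at a limit of the assay, and it differs from compound 4 in more than one place: the limit of < 1000 nM in this assay, at which 1 of the 4 values shown sits.

The compounds shown leave open whether a pyridin-4-yl group without the fluorine would read the same at this position. They also leave open how a morpholine ring or a dimethylamino group would read on the same carbonyl carbon.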